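Methyl on the Fused Ring Nitrogen of Compound 1

A few compounds are considered here, and "the series" means these few. Any claim that something is new, unique, unknown or untested is made for them only; others in the source may bear on it.

Measured compounds:
- compound 1, `O=C(Nc1ccc(Oc2ccnc3[nH]ccc23)cc1)c1nn(-c2ccc(Cl)cc2)ccc1=O`: 25100 nM
- compound 2, `O=C(Nc1ccc(Oc2ccnc3[nH]ccc23)cc1)c1nn(-c2ccccc2)ccc1=O`: 10500 nM
- compound 3, `O=C(Nc1ccc(Oc2ccnc3[nH]ccc23)cc1)c1nn(-c2ccc(Br)cc2F)ccc1=O`: 26100 nM

In a functional assay on A549 cells (Homo sapiens) for cytotoxicity, read by MTT assay, with a stated time of 72 h (on this read-out lower numbers stand for stronger inhibition and higher numbers for weaker inhibition), compound 1 stands second highest of the three numbers. Its nearest neighbour is compound 3, with a 1.0-fold higher number from compound 1 to compound 3 (0.02 log units; within the scatter); its furthest is compound 2, with a 2.4-fold lower number from compound 1 to compound 2 (0.38 log units; beyond the scatter). The remaining measured step, a 2.5-fold higher number from compound 2 to compound 3 (0.40 log units; beyond the scatter), is of the same modest size.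

Compound 4, `Cn1ccc2c(Oc3ccc(NC(=O)c4nn(-c5ccc(Cl)cc5)ccc4=O)cc3)ccnc21`, differs from compound 1 by methyl in place of hydrogen on an aromatic nitrogen. All three measured steps change the aryl group on the other aromatic nitrogen and leave the fused ring untouched, so none of them bears directly on this change. For the measured compounds named here, the shared core otherwise stays the same, and the data give no step at this position in either direction. Going by the values given here, the only guide is therefore the general spread of the three numbers, which is narrow.

On that basis compound 4 is expected to stay close to compound 1, with the estimated step of a 1.0-fold lower number from compound 1 to compound 4 (0.00 log units; within the scatter) not going beyond the scatter. Compound 4 is accordingly estimated at 25000 nM in this assay, with a range from 8000 nM to 80000 nM.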

Compound 4, half-maximal inhibitory concentration: > 60000 nM
Compound 4: no number, only a limit; the forecaster's own chance of this, stated with the estimate: 10%; at least 2.4-fold (0.38 log units) between middle value and limit.
By their numbers in this assay, from the lowest: compound 2; then compounds 1 and 3 (each within the scatter of the next). At a limit, above all of these: compound 4.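

In this assay compound 4 gives no number, only a limit of the assay, > 60000 nM. With methyl in place of hydrogen on the aromatic nitrogen of the five-membered ring, the read-out shows an at least 2.3-fold higher number from compound 1 to compound 4 (0.37 log units; beyond the scatter), the first step at this position among the compounds shown, and it points towards weaker inhibition, whereas every earlier step changed only the aryl group on the other aromatic nitrogen. This position therefore responds to change, even though the full size of the step cannot be read from a limit: the limit of > 60000 nM in this assay, at which 1 of the 4 values shown sits.

The compounds shown leave open whether the shift comes from the added methyl itself or from the absence of the hydrogen on that nitrogen, and whether an ethyl or a 2-hydroxyethyl group there would move the read-out in the same direction. They also leave open whether methyl at this position would act in the same way when paired with the phenyl of compound 2 or the 4-bromo-2-fluorophenyl of compound 3.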